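The source may report more compounds than this note shows. Statements on the series, on what has been measured and on what is new or still open speak of the compounds shown alone.

Compound 1 `CN(C)c1ncc(C(=O)Nc2ccccn2)nc1Cl`: 158 nM
Compound 2 `CC(C)Nc1nc(N)c(C(=O)Nc2ccccn2)nc1Cl`: 23 nM

Both compounds were tested in an assay on Ltk cells for inhibition of metabotropic glutamate receptor 5 (Homo sapiens), read by fluorescence; a lower number here means a stronger inhibitor, a higher number a weaker inhibitor. In this assay compound 1 gives 158 nM, and compound 2 gives 23 nM. Within the data shown here, of these two numbers, compound 2 has the lower one, which here means the stronger inhibition; the only comparison is with compound 1, whose number is higher by an amount that lies beyond the usual scatter of this kind of measurement.

Compound 3 `Nc1ncc(Cl)nc1C(=O)Nc1ccccn1` has not yet been measured. It differs from compound 2 in a single place: hydrogen in place of isopropylamino on an aromatic carbon. In words, the isopropylamino group is stripped off and a bare hydrogen stands in its place, while everything else in the molecule is kept.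

Among the measured compounds shown here, no pair of measured compounds that differ in only one place is available, so the size of this change cannot be read from an earlier result. The expectation is that compound 3 inhibits less strongly than compound 2, with a step larger than the scatter, of roughly a 6.5-fold higher number from compound 2 to compound 3 (0.81 log units; beyond the scatter). Compound 3 is therefore estimated at about 150 nM in this assay, expected to fall between 40 nM and 600 nM.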

Compound 3, half-maximal inhibitory concentration: 11 nM
Estimate against measurement, compound 3: 14-fold (1.13 log units) above; measured number outside the range, below it.
By their numbers in this assay, from the lowest: compound 3; then compound 2; then compound 1.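

In this assay, swapping the isopropylamino group for hydrogen gives a 2.1-fold lower number from compound 2 to compound 3 (0.32 log units; beyond the scatter), a modest step but one beyond the usual scatter. This shows that inhibition does not depend on the isopropylamino group at this position: its 4 heavy atoms, including 1 hydrogen-bond donor and 1 hydrogen-bond acceptor, can be removed without any loss of inhibition, and the bare hydrogen does slightly better. This single step does not show that the position favours hydrogen over every other group, and no measurement shown here explains why the stripped-down compound 3 inhibits more strongly than compound 2.

The compounds shown leave open what a methyl group, a methoxy group, a smaller amine such as methylamino or a longer chain such as butylamino would do on this same aromatic carbon, so it remains unknown whether any group there can beat hydrogen. They also leave open whether the step would look the same if the amino group or the chloro group on the ring were replaced, for example by a methyl group.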